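Removing a Methyl Next to the Ring Nitrogen

The source may report more compounds than this note shows. Statements on the series, on what has been measured and on what is new or still open speak of the compounds shown alone.

Compound 1: `Cc1cnc2nc(-c3ccc(F)cc3)cc(O)c2c1` — 24000 nM
Compound 2: `Cc1cc(C)c2c(O)cc(-c3ccc(Cl)cc3)nc2n1` — 14800 nM
Compound 3: `COc1cccc(-c2cc(O)c3c(C)cc(C)nc3n2)c1` — 407 nM

Of the compounds shown here, three on a shared core have been tested in a functional assay on HCT-116 cells (Homo sapiens); a higher number here means a weaker inhibitor of growth, a lower number a stronger inhibitor of growth. Compound 1 gives 24000 nM and compound 2 gives 14800 nM. Compound 3 stands lowest of the three with 407 nM; its gap to compound 2 and its gap to compound 1 both lie beyond the scatter, so compound 3 is the strongest growth inhibitor among them. These compounds differ from one another in more than one place, so no single change can be read from their values.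

Compound 4, `COc1cccc(-c2cc(O)c3c(C)ccnc3n2)c1`, has not yet been measured in this assay. It differs from compound 3 in one place: hydrogen in place of methyl on an aromatic carbon The methyl leaves from the aromatic carbon next to the ring nitrogen, and a hydrogen enters there. Going by the values given here, no measured pair shows this exact change, so the expectation rests on the general observation that small groups on this core seem to matter, with no direct evidence in either direction. The expected step of a 2.0-fold higher number from compound 3 to compound 4 (0.29 log units; within the scatter) is a modest weakening, possibly within the scatter. Compound 4 is expected to give about 800 nM, within 250 nM to 2500 nM.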

Compound 4, concentration for 50% growth inhibition: 44.7 nM
Estimate against measurement, compound 4: 18-fold (1.25 log units) above, and the stated range ends above it.
By their numbers in this assay, from the lowest: compound 4; then compound 3; then compounds 2 and 1 (each within the scatter of the next).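

In this assay, replacing the methyl on the aromatic carbon next to the ring nitrogen with hydrogen gives a 9.1-fold lower number from compound 3 to compound 4 (0.96 log units; beyond the scatter), a step beyond the scatter toward stronger growth inhibition. Going by these compounds alone, this is the only comparison so far that changes a single place, and it shows that this methyl is not needed for growth inhibition in this pair: with everything else held the same, the compound carrying hydrogen there is the stronger inhibitor. No accompanying data bear on this change, so the reason for the gain remains unknown.

Hydrogen and methyl are the only two groups compared at this position, so it remains open how a fluorine, a methoxy group or an amine would behave there. On these data alone, it is also open whether the same change would strengthen compound 2, which carries a different aryl group.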